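Hydroxy to hydrogen on compound 2: series notes

This account rests on a few compounds, and the source may have more. Where it says the series, first, only, none or still open, it means among the compounds named here.

Measured in a functional assay on HepG2 cells (Homo sapiens) for antiproliferative activity; a lower number here means a stronger inhibitor, a higher number a weaker inhibitor
compound 1 `CC[C@H](C)[C@H]1C(=O)N[C@H](Cc2cc(Cl)c(O)c(Cl)c2)C(=O)N[C@@H](C(C)C)C(=O)O[C@H](c2ccccc2)[C@H](C)/C=C/C=C(\C)[C@H](OC)C[C@@H]2O[C@@]2(C)C(=O)N1C` gives 5.65 nM
compound 2 `CC[C@H](C)[C@H]1C(=O)N[C@H](Cc2ccc(O)c(Br)c2)C(=O)N[C@@H](C(C)(C)O)C(=O)O[C@H](c2ccccc2)[C@H](C)/C=C/C=C(\C)[C@H](OC)C[C@@H]2O[C@@]2(C)C(=O)N1C` gives 2.98 nM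
compound 3 `CC[C@H](C)[C@H]1C(=O)N[C@H](Cc2cc(Cl)c(O)c(Cl)c2)C(=O)N[C@@H](C(C)(C)O)C(=O)O[C@H](c2ccccc2)[C@H](C)/C=C/C=C(\C)[C@H](OC)C/C=C(\C)C(=O)N1C` gives 2.75 nM

Compound 2 lies within the scatter of both compound 1 and compound 3, so its place among these numbers sets no order. Compound 4 `CC[C@H](C)[C@H]1C(=O)N[C@H](Cc2ccc(O)c(Br)c2)C(=O)N[C@@H](C(C)C)C(=O)O[C@H](c2ccccc2)[C@H](C)/C=C/C=C(\C)[C@H](OC)C[C@@H]2O[C@@]2(C)C(=O)N1C` follows from compound 2 through the change hydrogen in place of hydroxy on a saturated chain carbon bound to two saturated chain carbons and a saturated ring carbon (1-hydroxy-1-methylethyl to isopropyl). Within the data shown here, no measured pair isolates this change. Compound 1 also carries isopropyl and gives 5.65 nM in this assay but has different ring halogens, so it is only a loose guide. A small move to a higher number is expected, within the scatter. The expected change is a 1.7-fold higher number from compound 2 to compound 4 (0.22 log units; within the scatter) in this assay on this reading. The estimated value for compound 4 is 5 nM (expected range 2.2 nM to 11 nM).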

Compound 4, half-maximal inhibitory concentration: 6.84 nM
Compound 4: middle estimate off by 1.4-fold (0.14 log units), on the low side; low and high end bracket the measured number.
By their numbers in this assay, from the lowest: compounds 3, 2, 1 and 4 (each within the scatter of the next, the first and the last beyond it).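

In this assay, hydrogen in place of hydroxy on this saturated chain carbon gives a 2.3-fold higher number from compound 2 to compound 4 (0.36 log units; beyond the scatter), so 1-hydroxy-1-methylethyl to isopropyl now reads as a modest step beyond the scatter. With isopropyl held constant, 3-bromo-4-hydroxyphenyl in place of 3,5-dichloro-4-hydroxyphenyl gives a 1.2-fold higher number from compound 1 to compound 4 (0.08 log units; within the scatter), so the two ring patterns stay within the scatter in this pair. As far as these compounds go, whether the hydroxy step carries over to the 3,5-dichloro-4-hydroxyphenyl compounds remains open. Also open, from the compounds shown here alone, is what a methoxy or an amine would give in place of this hydroxy. No measured evidence bears on the cause of the step.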